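Adding a Third Methoxy to Compound 1

The compounds below may be only part of what the source reports. "The series", "measured", "known", "first", "only" and "open" are said of these compounds alone.

Compound 1 `C=CCn1c(SCC(=O)c2ccccc2)nnc1-c1ccc(OC)c(OC)c1` gives 72% in a functional assay on the whole organism (strain albino) for inhibition, with Rattus norvegicus as the target, read by paw edema, with a stated time of 4 h, at a dose of 0.28 mmol/kg by the oral route (on this read-out higher numbers stand for more inhibition at the one dose given (going by the name of the read-out) and lower numbers for less inhibition), the second highest of the three numbers in hand. Its nearest neighbour is compound 3 `CCn1c(SCC(=O)c2ccccc2)nnc1-c1ccc(OC)c(OC)c1` at 73%, the step of a number 1 percentage points higher from compound 1 to compound 3 (within the scatter); furthest is compound 2 `C=CCn1c(SCC(=O)c2ccccc2)nnc1-c1ccc(OC)cc1` at 67%, the step of a number 5 percentage points lower from compound 1 to compound 2 (within the scatter). Compound 4 `C=CCn1c(SCC(=O)c2ccccc2)nnc1-c1cc(OC)c(OC)c(OC)c1` differs from compound 1 in one place: methoxy in place of hydrogen on an aromatic carbon. The step that bears on this is the one removing a methoxy, a number 5 percentage points lower from compound 1 to compound 2 (within the scatter), which was within the scatter; adding one is therefore expected to move this assay little, with no step beyond the scatter in either direction, estimated as a number 1 percentage points higher from compound 1 to compound 4 (within the scatter). Compound 4 is expected to give about 73%, between 60% and 84%.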

Compound 4, a percentage reported as inhibition, in the whole organism at one dose (the size of the read-out at that dose, not a potency): 66%
The estimate for compound 4 lay 7 percentage points above the measured number; the range from low to high includes it.
By their numbers in this assay, from the lowest: compounds 4, 2, 1 and 3 (each within the scatter of the next).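

In this assay, a methoxy on the aromatic carbon ortho to a methoxy group and meta to a large group changes little (a number 6 percentage points lower from compound 1 to compound 4 (within the scatter)). Adding a methoxy thus stays within the scatter, as removing one does (a number 5 percentage points lower from compound 1 to compound 2 (within the scatter)), so neither change from compound 1 separates it from its neighbour on this read-out. No measurement bears on why the number falls where it does.

On these data alone, whether a hydroxyl, an amine or a carboxylic acid on this aromatic carbon would move the number beyond the scatter remains open. A read-out at one dose also leaves relative potency open.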